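Benzyl ether in place of the oxanylmethyl ether

The source may report more compounds than this note shows. Statements on the series, on what has been measured and on what is new or still open speak of the compounds shown alone.

Two members of the series have a number in a physicochemical assay for lipophilicity; on this read-out higher numbers stand for higher lipophilicity and lower numbers for lower lipophilicity. Compound 1 `O=C1NC(=O)C(Cc2ccc(OCC3CCCCO3)cc2)S1` gives 2.29 and stands lowest of the two; the nearest is compound 2 `CC(C)COc1ccc(/C=C2\SC(=O)NC2=O)cc1`, which in this assay gives 3.09, a figure beyond the scatter above compound 1. Going by the values given here, no pair differing in one place has been measured, so no step size is known from the data.

The next compound is compound 3 `O=C1NC(=O)C(Cc2ccc(OCc3ccccc3)cc2)S1`, which has not been measured in this assay. It differs from compound 1 as follows: phenyl in place of oxan-2-yl on a saturated chain carbon bound to an oxygen on an aromatic ring. The change removes a hydrogen-bond acceptor and replaces a non-aromatic ring with an aromatic one of carbon only.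

For compound 3 the step of a number 1.01 log units higher from compound 1 to compound 3 (beyond the scatter) is expected to be upward and beyond the scatter. Compound 3 is therefore estimated at 3.3, with a range from 2.8 to 3.8.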

Compound 3, partition coefficient: 3.67
Compound 3: middle estimate off by 0.37 log units, on the low side, within the range that was stated.
By their numbers in this assay, from the lowest: compound 1; then compound 2; then compound 3.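

In this assay, this pair gives the first size for a one-place change in the series: phenyl in place of oxan-2-yl, on a saturated chain carbon bound to an oxygen on an aromatic ring, is a large step, a number 1.38 log units higher from compound 1 to compound 3 (beyond the scatter). Both groups count 6 heavy atoms, so the step comes with no change in that count, while the ring becomes aromatic and the hydrogen-bond acceptor leaves. The ring oxygen and the aromatic character change together in this single pair, and no supporting measurement bears on what lies behind the step.

Open, as far as these compounds go, is how cyclohexyl at this place would read, since it would stand apart from both oxan-2-yl and phenyl in one feature each. Also open, from the compounds shown here alone, is whether pyridin-2-yl, or a longer chain carrying the phenyl, would keep a step of this size.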